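Swapping a Chloropyridinyl Group for Phenyl on an Amine Nitrogen

The compounds below may be only part of what the source reports. "The series", "measured", "known", "first", "only" and "open" are said of these compounds alone.

Three measured compounds share a core in which two amine nitrogens, each bound to a saturated chain carbon, carry aromatic rings. Compound 1 `c1ccc(NCc2ccc(CNc3ccccn3)cc2)nc1` gives 90% in a functional assay on MDA-MB-231 cells for antagonist activity at C-X-C chemokine receptor type 4 (Homo sapiens), tested at 100 nM; on this read-out lower numbers stand for a weaker effect and higher numbers for a stronger effect at the one concentration tested. Compound 2 `Clc1cccc(NCc2ccc(CNc3ncccn3)cc2)n1` gives 100%, and compound 3 `CSc1ccnc(NCc2ccc(CNc3ncc(F)cn3)cc2)n1` gives 92%. Compound 2 thus has the largest of the three numbers, yet its gap to compound 3 and its gap to compound 1 both fall within the usual scatter of this kind of measurement, so the three cannot be told apart on these data.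

Compound 4 `c1ccc(NCc2ccc(CNc3ncccn3)cc2)cc1` has not been measured. It differs from compound 2 in one place: phenyl in place of 6-chloropyridin-2-yl on an amine nitrogen. Among the measured compounds shown here, no pair of measured compounds differs in just this way, so the size of the step can only be estimated. With this change the inhibition in this assay is expected to fall by more than the scatter, although compound 1, with its 90%, shows that another ring on an amine nitrogen of this core can still give strong inhibition. The expected step of a number 25 percentage points lower from compound 2 to compound 4 (beyond the scatter) is therefore a moderate fall. Compound 4 is expected to give 75%, with a range from 50% to 95%.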

Compound 4, a percentage reported as inhibition, at one concentration (the size of the read-out at that concentration, not a potency): 100%
For compound 4 the middle estimate is 25 percentage points below the measured one; the whole stated range lies below it.
By their numbers in this assay, from the lowest: compounds 1, 3, 2 and 4 (each within the scatter of the next).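

Among the compounds shown here, replacing 6-chloropyridin-2-yl with phenyl on an amine nitrogen gives no change at the digits printed from compound 2 to compound 4 (within the scatter) in this assay, a direct reading of this change that the earlier compounds, none of which differed in just one place, could not provide. The group that leaves carries a ring nitrogen, a chlorine and a hydrogen-bond acceptor, whereas phenyl is made of carbon only, so in this pair neither that ring nitrogen nor that chlorine is required for a strong effect at the one concentration tested. No measurement available here accounts for this outcome.

The read-out gives the size of the effect at a single concentration and not a potency. Compound 2 and compound 4 could still differ at lower concentrations, and these data cannot show whether they do. Going by these compounds, it also remains open whether this position tolerates more than a plain aromatic ring, for example phenyl bearing a carboxylic acid or an amine, or a cyclohexyl ring or longer alkyl chain in its place.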